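Swapping the Substituent on the Ring Nitrogen

The compounds below may be only part of what the source reports. "The series", "measured", "known", "first", "only" and "open" are said of these compounds alone.

Compound 2 `COc1cc(C2=NN(C(=S)Nc3ccccc3)C(c3ccc(Cl)cc3)C2)ccc1O` and compound 1 `COc1cc(C2=NN(C(=O)c3ccccc3)C(c3ccc(Cl)cc3)C2)ccc1O` share one core and differ only in the group on an amine nitrogen in a ring. In an ADME assay on HepG2 cells (Homo sapiens) for cytotoxicity, read by MTT assay, with a stated time of 24 h, tested at 1 uM (a higher number here means a weaker effect of the compound at the concentration tested, a lower number a stronger effect), compound 2 gives 95%, the higher of the two numbers shown, and compound 1 gives 90%; the step of a number 5 percentage points higher from compound 1 to compound 2 (within the scatter) lies within the scatter. Compound 3 `COc1cc(C2=NN(C(=O)Oc3ccccc3)C(c3ccc(Cl)cc3)C2)ccc1O` carries a group of 9 heavy atoms (7 carbon, 2 oxygen; one six-membered aromatic ring of carbon only) in place of a group of 9 heavy atoms (7 carbon, 1 nitrogen, 1 sulfur; one six-membered aromatic ring of carbon only), on an amine nitrogen in a ring. Going by the values given here, the one measured step at this place, a number 5 percentage points higher from compound 1 to compound 2 (within the scatter), stayed within the scatter, so no step beyond the scatter is expected: a number 3 percentage points lower from compound 2 to compound 3 (within the scatter). Compound 3 is therefore estimated at 92%, between 80% and 102%.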

Compound 3, a percentage reported as activity, at one concentration (the size of the read-out at that concentration, not a potency): 93.1%
Compound 3: the middle estimate sits 1.1 percentage points below what was measured, and the stated range covers the measured number.
By their numbers in this assay, from the lowest: compounds 1, 3 and 2 (each within the scatter of the next).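

In this assay, phenoxycarbonyl on the amine nitrogen in the ring, in place of the sulfur-containing group, gives a number 1.9 percentage points lower from compound 2 to compound 3 (within the scatter), while phenoxy in place of phenyl on a carbonyl carbon gives a number 3.1 percentage points higher from compound 1 to compound 3 (within the scatter). All three groups at this nitrogen therefore read alike, and losing the hydrogen-bond donor of the group in compound 2 brings no step beyond the scatter. Nothing available explains this result. Still open, on these data alone, is whether an acetyl group, a longer alkyl chain or a carboxylic acid at this nitrogen would read the same. Also open, as far as these compounds go, is whether these compounds would separate at higher concentrations.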